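Trading the aminoethyl amide for a hydroxyethyl methyl amide

A few compounds are considered here, and "the series" means these few. Any claim that something is new, unique, unknown or untested is made for them only; others in the source may bear on it.

In a functional assay on PC-3 cells (Homo sapiens) for antiproliferative activity, read by MTT assay, with a stated time of 48 h (a higher number here means a weaker inhibitor, a lower number a stronger inhibitor), compound 1 `CCn1c(C(=O)NCCN)ccc1C(CC)(CC)c1ccc(OCCC(O)(CC)CC)c(C)c1` gives 2420 nM, the lowest of the two numbers measured. Compound 3 `CCn1c(C(=O)NC(CC(=O)O)C(=O)OC)ccc1C(CC)(CC)c1ccc(OCCC(O)(CC)CC)c(C)c1` gives 11200 nM, and the step of a 4.6-fold higher number from compound 1 to compound 3 (0.67 log units; beyond the scatter). Compound 2 `C#CCCOC(=O)c1ccc(C(CC)(CC)c2ccc(OCCC(O)(CC)CC)c(C)c2)n1CC` reaches only a limit of the assay, > 50000 nM, which is the limit of > 50000 nM in this assay, at which 1 of the 3 values shown sits. That step, an at least 20-fold higher number from compound 1 to compound 2 (1.31 log units; beyond the scatter), is large. Compound 4 `CCn1c(C(=O)N(C)CCO)ccc1C(CC)(CC)c1ccc(OCCC(O)(CC)CC)c(C)c1` differs from compound 1 by (2-hydroxyethyl)(methyl)amino in place of (2-aminoethyl)amino on a carbonyl carbon. Both measured changes at the carbonyl carbon raised the number in this assay, one modestly and one beyond the limit, so a modest to large rise is expected here as well. Compound 4 is therefore expected at 8000 nM, between 2500 nM and 30000 nM. This corresponds to an expected step of a 3.3-fold higher number from compound 1 to compound 4 (0.52 log units; beyond the scatter).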

Compound 4, half-maximal inhibitory concentration: 3090 nM
Compound 4: middle estimate off by 2.6-fold (0.41 log units), on the high side, and the stated range covers the measured number.
By their numbers in this assay, from the lowest: compounds 1 and 4 (each within the scatter of the next); then compound 3. At a limit, above all of these: compound 2.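

In this assay, a change on this carbonyl carbon need not raise the number: a 1.3-fold higher number from compound 1 to compound 4 (0.11 log units; within the scatter), so the amine end of the (2-aminoethyl)amino chain can give way to (2-hydroxyethyl)(methyl)amino with no step beyond the scatter. The bulkier amide group is a real difference, with a 3.6-fold lower number from compound 3 to compound 4 (0.56 log units; beyond the scatter). The amide also stands well clear of the ester, with an at least 16-fold lower number from compound 2 to compound 4 (1.20 log units; beyond the scatter), a step read from a limit: the limit of > 50000 nM in this assay, at which 1 of the 4 values shown sits.

The compounds shown do not separate the swap of amine for hydroxyl from the added methyl on the amide nitrogen. From the compounds shown here alone, how a longer chain ending in a hydroxyl, or a morpholine amide, would fare stays open.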